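Swapping the side chain for chlorine on the shared core

The compounds below may be only part of what the source reports. "The series", "measured", "known", "first", "only" and "open" are said of these compounds alone.

Compound 3, `COCc1c(C)nc2c(OCc3ccccc3)cccn12`, sits at the top of a small set in a functional assay on the whole organism with Rattus norvegicus as the target, with a stated time of 4 h, at a dose of 40 mg/kg by the intraperitoneal route (on this read-out lower numbers stand for less inhibition and higher numbers for more inhibition at the one dose given (going by the name of the read-out)), where compound 3 gives 99%. Compound 2, `Cc1nc2c(OCc3ccccc3)cccn2c1CO`, gives 99%, and the pair are level at the digits shown. Compound 1, `[C-]#[N+]Cc1c(C)nc2c(OCc3ccccc3)cccn12`, gives 96%, and the move a number 3 percentage points higher from compound 1 to compound 3 (within the scatter) and the move a number 3 percentage points higher from compound 1 to compound 2 (within the scatter) both stay within the scatter, as does the move no change at the digits printed from compound 2 to compound 3 (within the scatter). In short, the three measured compounds cannot be told apart.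

Compound 4, `Cc1nc2c(OCc3ccccc3)cccn2c1Cl`, changes the same spot once more: chloro in place of methoxymethyl on an aromatic carbon. Going by the values given here, none of the measured steps exchanges this side chain for a halogen, so none bears on the change directly. What the three steps do show is that altering the group at this position has not produced a step beyond the scatter, so for this assay no step beyond the scatter is expected either, a number 4 percentage points lower from compound 3 to compound 4 (within the scatter). Compound 4 is therefore estimated at 95%, within a range from 80% to 100%.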

Compound 4, a percentage reported as inhibition, in the whole organism at one dose (the size of the read-out at that dose, not a potency): 93%
Compound 4: middle estimate off by 2 percentage points, on the high side; low and high end bracket the measured number.
By their numbers in this assay, from the lowest: compounds 4, 1, 2 and 3 (each within the scatter of the next).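

Chlorine is the first group here that puts a single atom on this aromatic carbon in place of a side chain, and the exchange gives a number 6 percentage points lower from compound 3 to compound 4 (within the scatter) and a number 6 percentage points lower from compound 2 to compound 4 (within the scatter) and also a number 3 percentage points lower from compound 1 to compound 4 (within the scatter) in this assay. At this one dose, then, the read-out does not separate a lone chlorine from methoxymethyl, from hydroxymethyl or from the side chain of compound 1. Nothing available explains why these groups cannot be told apart here.

As far as these compounds go, it remains open whether a different kind of group at this position, such as an amine, a carboxylic acid or a longer chain, would give a step beyond the scatter. From the compounds shown here alone, it is also open whether these four compounds would still be alike at any dose other than the one given.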